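Bromo in Place of Iodo: Expected Cell Tolerance

This account rests on a few compounds, and the source may have more. Where it says the series, first, only, none or still open, it means among the compounds named here.

Measured so far:
compound 1, `O=C(/C=C/c1ccc([N+](=O)[O-])o1)c1ccc(I)cc1`, gives 49500 nM in an ADME assay on THP-1 cells (Homo sapiens) for cytotoxicity, read by resazurin assay, with a stated time of 72 h; a higher number here means that more compound is tolerated, a lower number that less compound is tolerated.
compound 2, `COc1ccc(/C=C/C(=O)c2cccc(Br)c2)cc1`, gives only a limit of the assay in this assay, > 50000 nM.

Among the measured compounds shown here, compound 1 holds the only real number in this assay, since the value of compound 2 is a limit rather than a measurement (the limit of > 50000 nM in this assay, at which 1 of the 2 values shown sits). For the measured compounds named here, with just these two results, and no measured step between compounds that differ in a single place, there is no yardstick within the set for how a small change shifts tolerance.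

Compound 3, `O=C(/C=C/c1ccc([N+](=O)[O-])o1)c1ccc(Br)cc1`, is still to be measured in this assay. It differs from compound 1 in one place: bromo in place of iodo on an aromatic carbon.

Given the lack of any measured step, the expectation is a change no larger than the usual scatter of this assay, in either direction. Compound 3 is therefore expected to give about 49500 nM in this assay, plausibly between 25000 nM and 100000 nM. This estimate means a step of no change at the digits printed from compound 1 to compound 3 (within the scatter).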

Compound 3, half-maximal cytotoxic concentration: 13400 nM
Beside the measured number, compound 3's estimate is 3.7-fold (0.57 log units) above it, and the stated range ends above it.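

Bromo in place of iodo on this aromatic carbon, para to a large group, gives a 3.7-fold lower number from compound 1 to compound 3 (0.57 log units; beyond the scatter) in this assay. Among the compounds shown here, this is the first measured single-place step in the set, and it shows that exchanging one halogen for another at this position can move the result beyond the usual scatter, towards less compound being tolerated. Nothing in the data shown explains why this exchange has that effect.

Going by these compounds, whether a chloro or fluoro group, or an amine, at the same position would shift the number further in this direction or reverse it remains open. So does whether bromo in place of iodo would produce a step of similar size on a core other than the one shared by compound 1 and compound 3.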